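Aryl hydrazone series: trimethoxyphenyl to dihydroxyphenyl

The source may hold more compounds than are shown below. What is called first, only, known or untested is meant among the compounds shown, and "the series" means these compounds.

Measured in a functional assay on MKN-45 cells (Homo sapiens) for cytotoxicity, read by MTT assay, with a stated time of 72 h; on this read-out higher numbers stand for weaker inhibition and lower numbers for stronger inhibition:
compound 1 `CN(C)CCn1cnnc1-c1cc(Oc2ccc(NC(=O)N/N=C/c3c(Cl)cccc3Cl)cc2F)ccn1` gives 160 nM;
compound 2 `CN(C)CCn1cnnc1-c1cc(Oc2ccc(NC(=O)N/N=C/c3ccccc3)cc2F)ccn1` gives 2730 nM;
compound 3 `COc1cc(/C=N/NC(=O)Nc2ccc(Oc3ccnc(-c4nncn4CCN(C)C)c3)c(F)c2)cc(OC)c1OC` gives 2900 nM.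

Compound 3 stands at the highest number of the three, with compound 2 within the scatter of it and compound 1 far lower. The steps of a 17-fold higher number from compound 1 to compound 2 (1.23 log units; beyond the scatter) and an 18-fold higher number from compound 1 to compound 3 (1.26 log units; beyond the scatter) are both large, whereas a 1.1-fold higher number from compound 2 to compound 3 (0.03 log units; within the scatter) lies within the scatter. Compound 4 `CN(C)CCn1cnnc1-c1cc(Oc2ccc(NC(=O)N/N=C/c3ccc(O)c(O)c3)cc2F)ccn1` carries the change (3,4-dihydroxyphenyl in place of 3,4,5-trimethoxyphenyl on a carbon with a double bond to nitrogen). Within the data shown here, no measured step covers this group directly; the only one that bears on it, the exchange of phenyl for 3,4,5-trimethoxyphenyl, stayed within the scatter, and on that basis no step beyond the scatter is expected for compound 4 in this assay, a 1.0-fold lower number from compound 3 to compound 4 (0.02 log units; within the scatter). For compound 4 the estimate is 2800 nM, with a range from 900 nM to 9000 nM.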

Compound 4, half-maximal inhibitory concentration: 3240 nM
Beside the measured number, compound 4's estimate is 1.2-fold (0.06 log units) below it; measured number inside the range.
By their numbers in this assay, from the lowest: compound 1; then compounds 2, 3 and 4 (each within the scatter of the next).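

In this assay, 3,4-dihydroxyphenyl on a carbon with a double bond to nitrogen stays within the scatter of both 3,4,5-trimethoxyphenyl (a 1.1-fold higher number from compound 3 to compound 4 (0.05 log units; within the scatter)) and phenyl (a 1.2-fold higher number from compound 2 to compound 4 (0.07 log units; within the scatter)). Hydrogen-bond donors on this aryl group therefore bring no step beyond the scatter, while 2,6-dichlorophenyl remains apart (a 20-fold higher number from compound 1 to compound 4 (1.31 log units; beyond the scatter)). No measurement available here accounts for either finding.

Open: whether 2-chlorophenyl, 2,6-dibromophenyl or 2,6-dimethylphenyl would match the number of compound 1, and whether an amine or a carboxylic acid on the phenyl would move the number at all.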